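Anilide series on the shared core: removing one trifluoromethyl

The compounds below may be only part of what the source reports. "The series", "measured", "known", "first", "only" and "open" are said of these compounds alone.

Compound 1 `Nc1ncnc2c1ccn2-c1ccc(NC(=O)Nc2ccc(Cl)c(C(F)(F)F)c2)cc1` has a urea link; in an ADME assay on HS27 cells (Homo sapiens) for antiproliferative activity, read by MTT assay, with a stated time of 24 h (on this read-out lower numbers stand for stronger inhibition and higher numbers for weaker inhibition), compound 1 gives only a limit of > 10000 nM (the limit of > 10000 nM in this assay, at which 1 of the 3 values shown sits). Compound 2 `Nc1ncnc2c1ccn2-c1ccc(NC(=O)c2ccc(Cl)c(C(F)(F)F)c2)cc1` carries an amide in its place, and in this assay compound 2 gives 5600 nM. Compound 3 `O=C(Nc1ccc(-n2ccc3c(NC(=O)c4ccccc4)ncnc32)cc1)c1cc(C(F)(F)F)cc(C(F)(F)F)c1` adds a benzoyl amide on the shared core and a second trifluoromethyl on the distal ring; in this assay compound 3 gives 6600 nM, the higher of the two numbers, though compound 2 sits within the scatter of it. Compound 4 `O=C(Nc1ccc(-n2ccc3c(NC(=O)c4ccccc4)ncnc32)cc1)c1cccc(C(F)(F)F)c1` differs from compound 3 by hydrogen in place of trifluoromethyl on an aromatic carbon. For the measured compounds named here, no measured step of this kind exists here, so the change is expected to stay within the scatter, with compound 4 estimated at 7000 nM (range 3000 nM to 16000 nM); this estimate means a step of a 1.1-fold higher number from compound 3 to compound 4 (0.03 log units; within the scatter) expected to be no larger than the scatter.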

Compound 4, half-maximal inhibitory concentration: 5900 nM
Compound 4: the middle estimate sits 1.2-fold (0.07 log units) above what was measured, and the stated range covers the measured number.
By their numbers in this assay, from the lowest: compounds 2, 4 and 3 (each within the scatter of the next). At a limit, above all of these: compound 1.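

Hydrogen in place of trifluoromethyl gives a 1.1-fold lower number from compound 3 to compound 4 (0.05 log units; within the scatter) in this assay and is the first measured step at this position, on an aromatic carbon meta to a trifluoromethyl group. With the benzoyl amide on the shared core held constant, the two substituents are not told apart in this read-out, and one trifluoromethyl on the distal ring suffices to keep the number within the scatter.

An amine or a carboxylic acid at this position could still show whether the position responds to any change. No measurement shown gives a reason for this step.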